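The compounds below may be only part of what the source reports. "The series", "measured", "known", "first", "only" and "open" are said of these compounds alone.

In a functional assay on HeLa cells (Homo sapiens) for antiproliferative activity, with a stated time of 48 h (a higher number here means a weaker inhibitor, a lower number a stronger inhibitor), compound 1 (`C=C(Br)C(=O)Nc1ccc(/C=C/C(=O)c2ccccc2)cc1`) gives 3900 nM, compound 2 (`C=C(Br)C(=O)Nc1ccc(/C=C/C(=O)c2cccs2)cc1`) gives 340 nM and compound 3 (`C=C(Br)C(=O)Nc1ccc(C(=O)/C=C/c2ccccc2)cc1`) gives 960 nM, the second highest of the three numbers. Compound 4 (`C=C(Br)C(=O)Nc1ccc(C(=O)/C=C/c2ccccc2OC)cc1`) has methoxy in place of hydrogen on an aromatic carbon, ortho to a large group: methoxy in place of hydrogen on an aromatic carbon. Among the measured compounds shown here, the only measured step, an 11-fold lower number from compound 1 to compound 2 (1.06 log units; beyond the scatter), comes with thiophen-2-yl in place of phenyl on a carbonyl carbon. It is large, but it involves a different group at a different place, so it sets no direction here. In this assay, no step beyond the scatter is therefore expected, and the estimated change is a 1.2-fold lower number from compound 3 to compound 4 (0.08 log units; within the scatter). Compound 4 is estimated at 800 nM, with an expected range of 250 nM to 2500 nM.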

Compound 4, half-maximal inhibitory concentration: 1300 nM
Estimate against measurement, compound 4: 1.6-fold (0.21 log units) below; measured number inside the range.
By their numbers in this assay, from the lowest: compound 2; then compounds 3 and 4 (each within the scatter of the next); then compound 1.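

Among the compounds shown here, the earlier step concerned a different group at a different place, so this is the first reading at this position. In this assay, methoxy in place of hydrogen on an aromatic carbon, ortho to a large group, gives a 1.4-fold higher number from compound 3 to compound 4 (0.13 log units; within the scatter), so phenyl to 2-methoxyphenyl stays within the scatter. Nothing available explains this result.

On these data alone, it remains open whether an amine, a carboxylic acid or a longer chain at this position would give a step beyond the scatter. As far as these compounds go, whether methoxy would do the same on the phenyl of compound 1 is also open.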